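The source may hold more compounds than are shown below. What is called first, only, known or untested is meant among the compounds shown, and "the series" means these compounds.

Measured compounds:
compound 1, `CCCCCCCCCCCCS(=O)(=O)CC(O)(O)C(F)(F)F`: 0.398 nM
compound 2, `CCCCCCS(=O)(=O)CC(O)(O)C(F)(F)F`: 0.708 nM

In an assay on isolated protein for inhibition of liver carboxylesterase 1 (Homo sapiens), with a stated time of 24 h (on this read-out lower numbers stand for stronger inhibition and higher numbers for weaker inhibition), compound 1 gives 0.398 nM and compound 2 gives 0.708 nM. The two numbers lie within the scatter of each other, the step being a 1.8-fold higher number from compound 1 to compound 2 (0.25 log units; within the scatter), so compound 2 cannot be set apart from compound 1 on this read-out.

Compound 3, `CCCCCCCCCCS(=O)(=O)CC(O)(O)C(F)(F)F`, has not yet been measured. It differs from compound 2 by butyl in place of hydrogen on a saturated chain carbon, six bonds along the chain from a sulfonyl sulfur. Within the data shown here, the only measured step that bears on this change is the one from compound 1 to compound 2, which lengthened or shortened the same chain at the same place and stayed within the scatter, a 1.8-fold higher number from compound 1 to compound 2 (0.25 log units; within the scatter). Because that step, a 1.8-fold higher number from compound 1 to compound 2 (0.25 log units; within the scatter), was within the scatter, no step beyond the scatter is expected for compound 3 in this assay either; the expected step is a 1.4-fold lower number from compound 2 to compound 3 (0.15 log units; within the scatter). Compound 3 is therefore estimated at 0.5 nM, with a range from 0.25 nM to 1 nM.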

Compound 3, inhibition constant: 0.302 nM
Compound 3: middle estimate off by 1.7-fold (0.22 log units), on the high side; measured number inside the range.
By their numbers in this assay, from the lowest: compounds 3, 1 and 2 (each within the scatter of the next, the first and the last beyond it).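

In this assay, among these compounds, the butyl change gives a 2.3-fold lower number from compound 2 to compound 3 (0.37 log units; beyond the scatter) as the first step at this position to lie beyond the scatter, though it is a modest one. The change further along the chain, hydrogen in place of ethyl, gives a 1.3-fold lower number from compound 1 to compound 3 (0.12 log units; within the scatter) and leaves compound 1 and compound 3 indistinguishable, while compound 1, with the longest chain, also stays within the scatter of compound 2, so chain length does not set the three compounds in a simple order. Nothing shown here explains these numbers.

On these data alone, whether a chain shorter than that of compound 2, or longer than that of compound 1, would give a step beyond the scatter stays open. So does the effect of an amine or a carboxylic acid in place of butyl at this position.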